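Lengthening the chain on the shared core

This account rests on a few compounds, and the source may have more. Where it says the series, first, only, none or still open, it means among the compounds named here.

Measured in a functional assay, read by spectrophotometry, with a stated time of 1 h (on this read-out lower numbers stand for stronger inhibition and higher numbers for weaker inhibition), so far
compound 1 `CCCCCCCC(=O)OC(c1ccc(O)c(OC)c1)[C@H]1COC(=O)[C@@H]1Cc1ccc(O)c(OC)c1` gives 24100 nM
compound 2 `CCCCCCCCCCCC(=O)OC(c1ccc(O)c(OC)c1)[C@H]1COC(=O)[C@@H]1Cc1ccc(O)c(OC)c1` gives 24500 nM

Compound 2 at 24500 nM stands level with compound 1 at 24100 nM within the scatter. Compound 3 `CCCCCCCCCCCCCCCCCC(=O)OC(c1ccc(O)c(OC)c1)[C@H]1COC(=O)[C@@H]1Cc1ccc(O)c(OC)c1` carries hexyl in place of hydrogen on a saturated chain carbon, ten or more bonds along the chain from a carbonyl carbon relative to compound 2. Going by the values given here, the one measured step bearing on this is a 1.0-fold higher number from compound 1 to compound 2 (0.01 log units; within the scatter) and it also lengthened the chain, staying within the scatter. The estimated step in this assay is therefore a 1.1-fold higher number from compound 2 to compound 3 (0.03 log units; within the scatter) and none beyond the scatter is expected. Compound 3 is expected at 26000 nM with an estimated range from 14000 nM to 50000 nM on this read-out.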

Compound 3, half-maximal inhibitory concentration: 25200 nM
For compound 3 the middle estimate is 1.0-fold (0.01 log units) above the measured one; low and high end bracket the measured number.
By their numbers in this assay, from the lowest: compounds 1, 2 and 3 (each within the scatter of the next).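

Hexyl at this place gives a 1.0-fold higher number from compound 2 to compound 3 (0.01 log units; within the scatter) in this assay, and decyl, read over the whole stretch, gives a 1.0-fold higher number from compound 1 to compound 3 (0.02 log units; within the scatter), so the level reading now extends well past the single step seen earlier. Within the chains shown, compound 1, compound 2 and compound 3 therefore stand level, and added chain length alone does not separate them. No measurement at hand offers an explanation for this.

Open, from the compounds shown here alone, is whether a carboxylic acid or an amine at the chain end would move the number beyond the scatter. Also open, going by these compounds, is whether a much shorter chain, such as acetyl, would do so.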